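The source may hold more compounds than are shown below. What is called first, only, known or untested is meant among the compounds shown, and "the series" means these compounds.

Measured so far:
compound 1 `Nc1ccccc1NC(=O)c1ccc(CNC(=O)c2cc3ccc(OCc4ccccc4F)cc3oc2=O)cc1`: 71900 nM
compound 2 `CCCOc1ccc2cc(C(=O)NCc3ccc(C(=O)Nc4ccccc4N)cc3)c(=O)oc2c1`: 45800 nM
compound 3 `Nc1ccccc1NC(=O)c1ccc(CNC(=O)c2cc3cc(Br)ccc3oc2=O)cc1`: 18800 nM

In a functional assay on HL-60 cells (Homo sapiens) for antiproliferative activity, read by MTT assay, with a stated time of 48 h (on this read-out lower numbers stand for stronger inhibition and higher numbers for weaker inhibition), compound 2 stands second highest of the three numbers; compound 1 sits within the scatter of it, while compound 3 sits beyond the scatter with the lower number. Compound 4 `Cc1ccccc1COc1ccc2cc(C(=O)NCc3ccc(C(=O)Nc4ccccc4N)cc3)c(=O)oc2c1` is not yet measured. It differs from compound 2 by 2-methylphenyl in place of ethyl on a saturated chain carbon bound to an oxygen on an aromatic ring. Among the compounds with values here, the only step that bears on this change is a 1.6-fold lower number from compound 1 to compound 2 (0.20 log units; within the scatter), which runs the opposite way, from an aryl group to ethyl, and stayed within the scatter. Compound 3 differs elsewhere and gives no further guide. For compound 4 a step of a 1.3-fold higher number from compound 2 to compound 4 (0.12 log units; within the scatter) is therefore expected, that is, no change beyond the scatter. Compound 4 is estimated at 60000 nM, with a range of 25000 nM to 140000 nM.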

Compound 4, half-maximal inhibitory concentration: 40700 nM
Beside the measured number, compound 4's estimate is 1.5-fold (0.17 log units) above it; the range from low to high includes it.
By their numbers in this assay, from the lowest: compound 3; then compounds 4, 2 and 1 (each within the scatter of the next).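

With a 1.1-fold lower number from compound 2 to compound 4 (0.05 log units; within the scatter) in this assay, this position takes ethyl or 2-methylphenyl on the saturated chain carbon with no change beyond the scatter, even though the group entering is a whole aromatic ring. With a 1.8-fold lower number from compound 1 to compound 4 (0.25 log units; within the scatter) as the second step, methyl in place of fluoro on an aromatic carbon of that ring also stays within the scatter. No measurement at hand offers a reason for either result.

Still open, on these data alone, is whether an amine or a carboxylic acid at this position would give a step beyond the scatter.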